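The source may report more compounds than this note shows. Statements on the series, on what has been measured and on what is new or still open speak of the compounds shown alone.

Three fatty-acid amides have been measured in a functional assay on PC-3 cells (Homo sapiens) for antiproliferative activity, read by sulforhodamine B assay, with a stated time of 48 h; on this read-out higher numbers stand for weaker inhibition of growth and lower numbers for stronger inhibition of growth. Compound 1 `CCCCCC[C@@H](O)C/C=C\CCCCCCCC(=O)N[C@@H](C)c1ccccc1` gives 11.7 ug/mL. Compound 2 `CCCCCCCC/C=C\CCCCCCCC(=O)N1CCCCC1` gives 8.7 ug/mL, the lowest of the three numbers, though its gap to compound 1 lies within the scatter, so the two cannot be ordered; compound 3 `CCCCCCCCCCCCCCCC(=O)N1CCOCC1` gives 22.2 ug/mL, and only its gap to compound 2 lies beyond the scatter. Compound 4 `CCCCC/C=C\C/C=C\CCCCCCCC(=O)N1CCCCC1` has not yet been measured in this assay. It differs from compound 2 in one place: hept-1-en-1-yl in place of heptyl on a saturated chain carbon bound to a double-bonded chain carbon. Going by the values given here, no measured pair in this set isolates this change, so there is no step to lean on. The remaining chain and the piperidine amide are kept, and with nothing in the data pointing either way, the step expected here is small, a 1.2-fold lower number from compound 2 to compound 4 (0.06 log units; within the scatter), and is not expected to reach beyond the scatter. On that basis compound 4 is estimated at 7.5 ug/mL in this assay, with a likely range from 4 ug/mL to 14 ug/mL.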

Compound 4, concentration for 50% growth inhibition: 53.6 ug/mL
Compound 4: the middle estimate sits 7.1-fold (0.85 log units) below what was measured; the whole stated range lies below it.
By their numbers in this assay, from the lowest: compounds 2, 1 and 3 (each within the scatter of the next, the first and the last beyond it); then compound 4.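

Hept-1-en-1-yl in place of heptyl, on a saturated chain carbon bound to a double-bonded chain carbon, gives a 6.2-fold higher number from compound 2 to compound 4 (0.79 log units; beyond the scatter) in this assay and so shows that this place in the chain is sensitive to the change. Going by these compounds alone, the piperidine amide and the remaining chain are kept in this pair, which isolates the added double bond outside aromatic rings as the one difference, something no earlier pair could do. Nothing available accounts for the size of this step.

This single pair does not tell whether any added double bond at another place in the chain would give a similar step. Going by these compounds, how an alkyne at the same place, or a carboxylic acid in place of the piperidine amide, would read in this assay also remains open.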